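The source may report more compounds than this note shows. Statements on the series, on what has been measured and on what is new or still open speak of the compounds shown alone.

Compound 1 `Nc1cc(N)c2nc(-c3ccccc3)c(Oc3ccc(Cl)c(Cl)c3)nc2c1` gives 4070 nM in a functional assay on UO-31 cells (Homo sapiens) for inhibition, read by sulforhodamine B assay, with a stated time of 48 h; on this read-out lower numbers stand for stronger inhibition of growth and higher numbers for weaker inhibition of growth.
Compound 2 `CCOC(=O)[C@H](CCC(=O)O)NC(=O)c1ccc(CNc2nc3cc(N)cc(N)c3nc2-c2ccccc2)cc1` reaches only a limit of the assay in this assay, < 100000 nM, which is not a number.
Compound 3 `CCOC(=O)[C@H](CCC(=O)O)NC(=O)c1ccc(Oc2nc3cc(N)cc(N)c3nc2-c2ccccc2)cc1` gives 11200 nM in this assay.

The three compounds share one core and differ in the group attached to it. Of the two actual numbers, compound 1 holds the lower one; compound 3 sits above it, and that gap lies beyond the usual scatter of the method. For compound 2 there is only (the limit of < 100000 nM in this assay, at which 1 of the 3 values shown sits), so its place relative to the others cannot be set.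

Compound 4 `Nc1cc(N)c2nc(-c3ccccc3)c(Sc3ccc(Cl)c(Cl)c3)nc2c1` has not yet been measured in this assay. It differs from compound 1 in a single place: (3,4-dichlorophenyl)sulfanyl in place of 3,4-dichlorophenoxy on an aromatic carbon. Going by the values given here, nothing among the measured compounds tracks this exchange of an oxygen for a sulfur in the linker, so there is no measured step to lean on. With the change kept to the linking atom and the rest of compound 1 retained, the step is expected to be small and to stay within the scatter, a 1.2-fold lower number from compound 1 to compound 4 (0.07 log units; within the scatter). Compound 4 is therefore estimated at 3500 nM, with a likely range from 1200 nM to 12000 nM.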

Compound 4, concentration for 50% growth inhibition: 3800 nM
Estimate against measurement, compound 4: 1.1-fold (0.04 log units) below; the measured number falls inside the stated range.
By their numbers in this assay, from the lowest: compounds 4 and 1 (each within the scatter of the next); then compound 3.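

Going by these compounds alone, replacing 3,4-dichlorophenoxy with (3,4-dichlorophenyl)sulfanyl gives a 1.1-fold lower number from compound 1 to compound 4 (0.03 log units; within the scatter) in this assay, and this is the first measured exchange at this position in which only the linking atom changes. The earlier compounds shown here differ from one another in more than one place, whereas this pair shows that, on this aromatic carbon next to the ring nitrogen and with the rest of compound 1 retained, the read-out does not separate an oxygen linker from a sulfur linker. No measurement shown gives a reason for this result.

From the compounds shown here alone, it remains open whether the position would tolerate other links to the 3,4-dichlorophenyl group in the same way, such as an amine nitrogen, a methylene carbon, or a sulfur oxidised to a sulfoxide or a sulfone. Going by these compounds, it is also open whether the same exchange of oxygen for sulfur would leave the number unchanged in compound 3, which carries a much larger group in this place, or whether chlorine atoms are needed on the ring for the step to stay this small.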